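A pyridin-3-yl swap and clearance in microsomes

A few compounds are considered here, and "the series" means these few. Any claim that something is new, unique, unknown or untested is made for them only; others in the source may bear on it.

Measured so far in an ADME assay (liver) for metabolic stability, with Liver microsome (Homo sapiens) as the target, using microsomes and NADPH, with a stated time of 30 min, tested at 1 uM; on this read-out higher numbers stand for fast clearance and lower numbers for slow clearance
- compound 1 `CC(C)(O)C#Cc1cc(C(O)(C(F)(F)F)C(F)(F)F)cnc1N1CCN(S(=O)(=O)c2ccc(N)nc2)CC1` gives < 14 mL.min-1.g-1 as a limit of the assay
- compound 2 `Nc1ccc(S(=O)(=O)N2CCN(c3ncc(C(O)(C(F)(F)F)C(F)(F)F)cc3-c3ccccc3O)CC2)cn1` gives 22 mL.min-1.g-1 as a number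

For the measured compounds named here, compound 2 stands at 22 mL.min-1.g-1 and holds the only true number so far. Compound 1 has only a limit (the limit of < 14 mL.min-1.g-1 in this assay, at which 1 of the 2 values shown sits).

Compound 3 `Nc1ccc(S(=O)(=O)N2CCN(c3ncc(C(O)(C(F)(F)F)C(F)(F)F)cc3-c3cccnc3)CC2)cn1` is still to be measured. It carries this change from compound 2: pyridin-3-yl in place of 2-hydroxyphenyl on an aromatic carbon so pyridin-3-yl takes the place of 2-hydroxyphenyl. Going by the values given here, one measured step bears on that aromatic carbon, an at least 1.5-fold higher number from compound 1 to compound 2 (0.19 log units; that floor lies within the scatter) where 2-hydroxyphenyl entered, and its floor stays within the scatter. That gives no ground to expect a large move, only a slight drift towards slower clearance. The expected step is a 1.4-fold lower number from compound 2 to compound 3 (0.14 log units; within the scatter) and it is not expected to exceed the scatter. Compound 3 is expected at 16 mL.min-1.g-1 (estimated range 9 mL.min-1.g-1 to 30 mL.min-1.g-1).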

Compound 3, intrinsic clearance in microsomes: 17 mL.min-1.g-1
The estimate for compound 3 lay 1.1-fold (0.03 log units) below the measured number, and the stated range covers the measured number.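

In this assay, pyridin-3-yl on this aromatic carbon gives a 1.3-fold lower number from compound 2 to compound 3 (0.11 log units; within the scatter), so the read-out does not separate this ring from the 2-hydroxyphenyl ring it replaces, even though one has a ring nitrogen and the other a ring of carbon only. Set against the 3-hydroxy-3-methylbut-1-yn-1-yl group, pyridin-3-yl gives an at least 1.2-fold higher number from compound 1 to compound 3 (0.08 log units; that floor lies within the scatter), so a second aromatic ring at this place also shows no step that clears the scatter. Compound 1 has only a limit here, not a number, and so the true size of that step stays unknown: the limit of < 14 mL.min-1.g-1 in this assay, at which 1 of the 3 values shown sits.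

The compounds shown leave open whether any group on this carbon can move clearance beyond the scatter. Whether an amine, a carboxylic acid or a morpholine ring there would do so remains to be seen.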